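Permeability notes on the sulfonamide series, amide variation

The source may report more compounds than this note shows. Statements on the series, on what has been measured and on what is new or still open speak of the compounds shown alone.

Measured so far in an ADME assay on Caco-2 cells (Homo sapiens) for permeability, in the apical to basolateral direction; a higher number here means that the compound crosses the layer faster, a lower number that the compound crosses the layer more slowly:
- compound 1, `Cn1cncc1CN1CC(N(CC2CCN(C(=O)C(C)(C)C)CC2)S(=O)(=O)c2ccccn2)Cc2cc(C#N)ccc21`: 0.5 10^-6 cm/s
- compound 2, `Cn1cncc1CN1CC(N(CC2CCN(C(=O)c3ccccc3)CC2)S(=O)(=O)c2ccccn2)Cc2cc(C#N)ccc21`: 0.5 10^-6 cm/s
- compound 3, `Cn1cncc1CN1CC(N(Cc2cccc(-n3cccc3)c2)S(=O)(=O)c2ccccn2)Cc2cc(C#N)ccc21`: 2.3 10^-6 cm/s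

Compound 2 stands level with compound 1 at the digits shown, and together the two give the lowest of the three numbers; compound 3 sits apart from them, with a 4.6-fold higher number from compound 1 to compound 3 (0.66 log units; beyond the scatter). The step from compound 1 to compound 2 exchanges the group on the carbonyl carbon, and there no change at the digits printed from compound 1 to compound 2 (within the scatter).

Compound 4, `CCCC(=O)N1CCC(CN(C2Cc3cc(C#N)ccc3N(Cc3cncn3C)C2)S(=O)(=O)c2ccccn2)CC1`, has not been measured yet. It differs from compound 2 in one place: propyl in place of phenyl on a carbonyl carbon. Among the compounds with values here, the measured step that bears on this change is the one from compound 1 to compound 2, where another exchange of the group on the carbonyl carbon gave no change at the digits printed from compound 1 to compound 2 (within the scatter). The step to compound 3 alters a different part of the molecule and says nothing about the carbonyl carbon. On that basis no step beyond the scatter is expected in this assay for compound 4, that is, no change at the digits printed from compound 2 to compound 4 (within the scatter) is the expected outcome. Compound 4 is therefore estimated at 0.5 10^-6 cm/s, within a range from 0.25 10^-6 cm/s to 1 10^-6 cm/s.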

Compound 4, apparent permeability: 0.5 10^-6 cm/s
The estimate for compound 4 equals the measured number at the digits printed, within the range that was stated.
By their numbers in this assay, from the lowest: compounds 1, 2 and 4 (each within the scatter of the next); then compound 3.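

In this assay, the exchange on the carbonyl carbon now extends beyond the earlier pair of tert-butyl and phenyl to a group with no ring: there is no change at the digits printed from compound 2 to compound 4 (within the scatter) and also no change at the digits printed from compound 1 to compound 4 (within the scatter). Propyl, with 3 heavy atoms, therefore takes the place of phenyl, with 6 heavy atoms and a six-membered aromatic ring, without a step beyond the scatter, so at this position neither that ring nor the branched tert-butyl group is needed to hold the number where it stands. Within the data shown here, the exchange on the saturated chain carbon bound to a sulfonamide nitrogen remains the only change here that moves the number, now also with propyl on the carbonyl carbon: there is a 4.6-fold lower number from compound 3 to compound 4 (0.66 log units; beyond the scatter).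

No measurement at hand gives a reason for either the flat result on the carbonyl carbon or the step on the chain carbon. Every group shown on the carbonyl carbon is built of carbon only, so whether an amine, a carboxylic acid or a longer chain at this place would leave the number level remains open.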